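The compounds below may be only part of what the source reports. "The series", "measured", "known", "first", "only" and "open" are said of these compounds alone.

Compound 3 `COc1ccc(CN2C(=O)C(=O)c3cc(-c4ccc(C(C)(C)C)cc4)ccc32)cc1` gives 2250 nM in a functional assay on K562 cells (Homo sapiens) for antiproliferative activity, read by MTT assay, with a stated time of 48 h (on this read-out higher numbers stand for weaker inhibition and lower numbers for stronger inhibition), the lowest of the two numbers shown. Compound 2 `COc1ccc(-c2ccc3c(c2)C(=O)C(=O)N3)cc1` gives 6920 nM in this assay, a number beyond the scatter from that of compound 3. Compound 1 `Cc1ccc(-c2ccc3c(c2)C(=O)C(=O)N3)cc1` reaches only the limit of the assay, > 10000 nM in this assay (the limit of > 10000 nM in this assay, at which 1 of the 3 values shown sits). Compound 4 `COc1ccc(CN2C(=O)C(=O)c3cc(-c4ccncc4)ccc32)cc1` differs from compound 3 in one place: pyridin-4-yl in place of 4-(tert-butyl)phenyl on an aromatic carbon. Among the compounds with values here, the only measured step, an at least 1.4-fold lower number from compound 1 to compound 2 (0.15 log units; that floor lies within the scatter), concerns a different change and does not bear on this one, so the data give no direction for the step. One therefore expects compound 4 to give about 4000 nM in this assay, somewhere between 1000 nM and 15000 nM. That estimate means a step of a 1.8-fold higher number from compound 3 to compound 4 (0.25 log units; within the scatter) in this assay, with a real chance that only a limit is reported.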

Compound 4, half-maximal inhibitory concentration: 40 nM
Beside the measured number, compound 4's estimate is 100-fold (2.00 log units) above it, and the stated range ends above it.
By their numbers in this assay, from the lowest: compound 4; then compound 3; then compound 2. At a limit, above all of these: compound 1.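

In this assay, pyridin-4-yl in place of 4-(tert-butyl)phenyl on this aromatic carbon gives a 56-fold lower number from compound 3 to compound 4 (1.75 log units; beyond the scatter), the first single change shown whose step lies beyond the scatter. The substituent on this carbon can therefore move the number strongly, which the earlier methoxy-for-methyl step could not show. Nothing measured here accounts for the size of this step. The change removes the tert-butyl group and brings in a ring nitrogen together, and the compounds shown do not separate the two. Open too, on these data alone, is what a plain phenyl or a pyridin-3-yl on this carbon would give.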